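From 2-methoxyphenyl to 3-hydroxyphenyl on a shared core

A few compounds are considered here, and "the series" means these few. Any claim that something is new, unique, unknown or untested is made for them only; others in the source may bear on it.

In a physicochemical assay for solubility, read by spectrophotometry, in phosphate buffer, with a stated time of 18 h, at pH 7.4 (on this read-out lower numbers stand for lower solubility and higher numbers for higher solubility), compound 1 (`CCc1ccc(-c2nc3c(c(C)nn3-c3ccccc3)c(-c3ccccc3C)c2C#N)cc1`) gives 6000 nM as its reading, compound 2 (`CCc1ccc(-c2nc3c(c(C)nn3-c3ccccc3)c(-c3ccccc3S(C)(=O)=O)c2C#N)cc1`) gives 2200 nM as its reading and compound 3 (`CCc1ccc(-c2nc3c(c(C)nn3-c3ccccc3)c(-c3ccccc3OC)c2C#N)cc1`) gives 7800 nM as its reading. Compound 3 thus shares the upper end of the three with compound 1: the step (a 1.3-fold higher number from compound 1 to compound 3 (0.11 log units; within the scatter)) lies within the scatter, whereas the step (a 3.5-fold higher number from compound 2 to compound 3 (0.55 log units; beyond the scatter)) lies beyond it. Compound 4 (`CCc1ccc(-c2nc3c(c(C)nn3-c3ccccc3)c(-c3cccc(O)c3)c2C#N)cc1`) differs from compound 3 at one place (3-hydroxyphenyl in place of 2-methoxyphenyl on an aromatic carbon) with 3-hydroxyphenyl in place of 2-methoxyphenyl on the aromatic carbon opposite the ring nitrogen. Going by the values given here, no measured compound carries 3-hydroxyphenyl, so the evidence is indirect. All three measured steps occur at this same place, and the two that pass the scatter involve compound 2 (a 2.7-fold lower number from compound 1 to compound 2 (0.44 log units; beyond the scatter) and a 3.5-fold higher number from compound 2 to compound 3 (0.55 log units; beyond the scatter)) and are modest. A step within the scatter, without a firm direction, is therefore expected: the estimated step is (a 1.3-fold lower number from compound 3 to compound 4 (0.11 log units; within the scatter)) in this assay terms. For compound 4 the estimate is 6000 nM with an expected range from 2500 nM to 15000 nM in this measurement.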

Compound 4, solubility: 18000 nM
The estimate for compound 4 lay 3.0-fold (0.48 log units) below the measured number; the whole stated range lies below it.
By their numbers in this assay, from the lowest: compound 2; then compounds 1 and 3 (each within the scatter of the next); then compound 4.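

In this assay, the aromatic carbon opposite the ring nitrogen now gives a rise beyond the scatter from the top of the series (a 2.3-fold higher number from compound 3 to compound 4 (0.36 log units; beyond the scatter) and a 3.0-fold higher number from compound 1 to compound 4 (0.48 log units; beyond the scatter)). Going by these compounds alone, until now, the only steps beyond the scatter at this position involved the low reading with 2-(methylsulfonyl)phenyl, whereas 3-hydroxyphenyl shows that the number can also move above the level of 2-methylphenyl and 2-methoxyphenyl, and the span at this position widens (an 8.2-fold higher number from compound 2 to compound 4 (0.91 log units; beyond the scatter)). Nothing measured here accounts for this rise. The compounds shown do not tell whether the step belongs to the hydroxy group or to its place on the phenyl ring, as hydroxy and methoxy are never compared at one place on that ring. They also leave open how an amine or a carboxylic acid on that ring would read.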